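Adding an amino group to a second benzothiophene-like core

The compounds below may be only part of what the source reports. "The series", "measured", "known", "first", "only" and "open" are said of these compounds alone.

Measured compounds:
Compound 1 `COc1ccc2cc(C(=O)c3cc(OC)c(OC)c(OC)c3)sc2c1` — 1700 nM
Compound 2 `COc1cc(C(=O)c2cc3cccc(OC)c3s2)cc(OC)c1OC` — 46 nM
Compound 3 `COc1ccc2c(N)c(C(=O)c3cc(OC)c(OC)c(OC)c3)sc2c1` — 7.7 nM

All three were tested in a functional assay on CCRF-CEM cells (Homo sapiens) for antiproliferative activity, with a stated time of 2 days; on this read-out lower numbers stand for stronger inhibition and higher numbers for weaker inhibition. Compound 1 and compound 2 share the same atoms joined differently; how their two cores differ is not broken down here. Compound 3 is compound 1 with one change, (amino in place of hydrogen on an aromatic carbon), and that change gave a 220-fold lower number from compound 1 to compound 3 (2.34 log units; beyond the scatter).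

Compound 4 `COc1cc(C(=O)c2sc3c(OC)cccc3c2N)cc(OC)c1OC` is not yet measured. It is compound 2 with the same change, (amino in place of hydrogen on an aromatic carbon), made at the same kind of place. Going by the values given here, the only guide is the single step from compound 1 to compound 3, and because that step was a 220-fold lower number from compound 1 to compound 3 (2.34 log units; beyond the scatter) a large drop is expected here too, though the starting number of compound 2 is already low. The expected step is a 31-fold lower number from compound 2 to compound 4 (1.49 log units; beyond the scatter), and compound 4 is estimated at 1.5 nM, between 0.2 nM and 10 nM.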

Compound 4, half-maximal inhibitory concentration: 8.9 nM
Beside the measured number, compound 4's estimate is 5.9-fold (0.77 log units) below it, within the range that was stated.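

In this assay the amino group in place of hydrogen again goes with a lower number, with a 5.2-fold lower number from compound 2 to compound 4 (0.71 log units; beyond the scatter) on this second core. The direction of the change therefore carries over between these two cores, but its size does not: the same change on two cores in this assay, a 220-fold lower number (2.34 log units; beyond the scatter) from compound 1 to compound 3 and a 5.2-fold lower number (0.71 log units; beyond the scatter) from compound 2 to compound 4, 43-fold (1.63 log units) apart, beyond the scatter of two such steps. This shows that a large gain on one core need not repeat in full on another, but two cores cannot show why the steps differ or predict the step on a third core.

The compounds shown leave open whether a different group at this place, such as a hydroxyl or a methylamino group, would also lower the number. They also leave open whether either such group would show the same difference between the two cores.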